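Second Trifluoromethyl on the Sulfone Series: Expected Gain

This account rests on a few compounds, and the source may have more. Where it says the series, first, only, none or still open, it means among the compounds named here.

Measured compounds in a functional assay on CWR22R cells (Homo sapiens) for antiproliferative activity, read by propidium iodide staining, with a stated time of 96 h; on this read-out higher numbers stand for weaker inhibition and lower numbers for stronger inhibition:
compound 1, `CC(O)(CSc1cccc(C(F)(F)F)c1)C(=O)Nc1cccc(S(F)(F)(F)(F)F)c1`, 12900 nM;
compound 2, `CC(O)(CSc1cc(C(F)(F)F)cc(C(F)(F)F)c1)C(=O)Nc1cccc(S(F)(F)(F)(F)F)c1`, 4400 nM;
compound 3, `CC(O)(CS(=O)(=O)c1cccc(C(F)(F)F)c1)C(=O)Nc1ccc(S(F)(F)(F)(F)F)cc1`, 23800 nM.

Compound 1 and compound 2 share one core and differ in one place, (trifluoromethyl in place of hydrogen on an aromatic carbon). That change gave a 2.9-fold lower number from compound 1 to compound 2 (0.47 log units; beyond the scatter) in this assay. Compound 3 has a different core; how it differs from compound 1 is not broken down here. Compound 3 stands at the highest number of the three: against compound 1 the gap is within the usual scatter, against compound 2 it is beyond it.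

Compound 4, `CC(O)(CS(=O)(=O)c1cc(C(F)(F)F)cc(C(F)(F)F)c1)C(=O)Nc1ccc(S(F)(F)(F)(F)F)cc1`, has not yet been measured. It relates to compound 3 in the same way that compound 2 relates to compound 1: trifluoromethyl in place of hydrogen on an aromatic carbon. The two place descriptions match word for word, so this is the same change made on the second core. Going by the values given here, the expectation for this assay is a step of about a 2.8-fold lower number from compound 3 to compound 4 (0.45 log units; beyond the scatter), resting on the single earlier step of a 2.9-fold lower number from compound 1 to compound 2 (0.47 log units; beyond the scatter); with only one precedent the uncertainty is wide. On that basis compound 4 is estimated at 8500 nM, with a range from 3500 nM to 20000 nM.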

Compound 4, half-maximal inhibitory concentration: 12700 nM
Beside the measured number, compound 4's estimate is 1.5-fold (0.17 log units) below it, within the range that was stated.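

On the second core, the added trifluoromethyl gave a 1.9-fold lower number from compound 3 to compound 4 (0.27 log units; within the scatter) in this assay. Set beside the earlier step, the two cannot be told apart: the same change on two cores in this assay, a 2.9-fold lower number (0.47 log units; beyond the scatter) from compound 1 to compound 2 and a 1.9-fold lower number (0.27 log units; within the scatter) from compound 3 to compound 4, 1.6-fold (0.19 log units) apart, within the scatter of two such steps. This fits a change that carries from one core to the other with a similar size, but it does not establish a real gain on the second core, since that step alone stays within the scatter, and two pairs say nothing about any further core.

The compounds shown leave open whether another group in place of the same hydrogen, such as a nitrile, a chlorine atom or an amine, would give a step of similar size. They also leave open whether the step would hold on a core with a longer chain in place of the methyl group on the carbon bearing the hydroxyl.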